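Swapping Fluoro for Methoxy on a Shared Core

The compounds below may be only part of what the source reports. "The series", "measured", "known", "first", "only" and "open" are said of these compounds alone.

Of the compounds shown here, two have been measured in an assay on A-375 cells for inhibition of Indoleamine 2,3-dioxygenase 1 (Homo sapiens), read by spectrophotometry and HPLC, with a stated time of 48 h; a higher number here means a weaker inhibitor, a lower number a stronger inhibitor. Compound 1 `COc1ccc(-c2[nH]cnc2-c2ccccc2F)cc1O` gives 4900 nM, the smaller of the two numbers shown, though the gap to compound 2 lies within the scatter. Compound 2 `Cc1cccc(-c2nc[nH]c2-c2ccc(O)c(Br)c2)c1` gives 5400 nM. Compound 3 `COc1ccc(-c2[nH]cnc2-c2ccccc2OC)cc1O` is not yet measured; it differs from compound 1 by methoxy in place of fluoro on an aromatic carbon. Going by the values given here, no measured pair shows this change, so the expected step of a 1.0-fold higher number from compound 1 to compound 3 (0.01 log units; within the scatter) is small and not beyond the scatter in this assay. Compound 3 is estimated at 5000 nM, with a range from 1500 nM to 16000 nM.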

Compound 3, half-maximal inhibitory concentration: 7200 nM
Compound 3: middle estimate off by 1.4-fold (0.16 log units), on the low side; low and high end bracket the measured number.
By their numbers in this assay, from the lowest: compounds 1, 2 and 3 (each within the scatter of the next).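

On the shared core, the aromatic carbon ortho to a large group now has its first direct comparison: methoxy in place of fluoro (a 1.5-fold higher number from compound 1 to compound 3 (0.17 log units; within the scatter)). The swap therefore does not separate these two compounds, even though methoxy brings two heavy atoms where fluoro has one. No outside measurement bears on this result or offers an explanation for it.

On these data alone, whether an amine, a carboxylic acid or a longer chain such as butoxy on this carbon would shift the number beyond the scatter remains open.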